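The source may report more compounds than this note shows. Statements on the series, on what has been measured and on what is new or still open speak of the compounds shown alone.

Three compounds have been examined in an ADME assay on HEK-293T cells (Homo sapiens) for inhibition, read by CCK-8 assay, with a stated time of 48 h, tested at 20 uM; on this read-out higher numbers stand for more inhibition of growth at the one concentration tested and lower numbers for less inhibition of growth. Compound 3 `COc1ccc(S(=O)(=O)Oc2ccccc2/C=C(\C#N)C(=O)Nc2nnc(Cc3ccc(C)cc3)s2)cc1` gives 28%, and compound 2 `N#C/C(=C\c1ccccc1OS(=O)(=O)c1ccccc1[N+](=O)[O-])C(=O)Nc1nnc(Cc2ccc(Cl)cc2)s1` gives 20%. This gap lies within the scatter, so the two cannot be separated. Compound 1 `N#C/C(=C\c1ccccc1OS(=O)(=O)c1ccccc1[N+](=O)[O-])C(=O)Nc1nnc(Cc2cccc(F)c2)s1` has no number and is recorded only as "not toxic" (no number reported). Among the compounds with values here, compound 3 therefore stands level with the one other compound that has a number, and both show modest inhibition of growth at the single concentration tested.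

Compound 4 `Cc1ccc(Cc2nnc(NC(=O)/C(C#N)=C/c3ccccc3OS(=O)(=O)c3ccccc3[N+](=O)[O-])s2)cc1` has not yet been measured. It differs from compound 3 by a single change: 2-nitrophenyl in place of 4-methoxyphenyl on a sulfonyl sulfur. Within the data shown here, no step between measured compounds isolates this change, so the data give no direct measure of its size. Compound 2 also carries 2-nitrophenyl on a sulfonyl sulfur and gives 20%, while compound 1, with the same group, has no number. These two compounds offer no sign of strong inhibition with this group, although neither is a direct comparison. In this assay the expected change is a number 6 percentage points lower from compound 3 to compound 4 (within the scatter), and no step beyond the scatter is expected. For compound 4 the estimated value is 22%, with an expected range from 8% to 38%.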

Compound 4, percent growth inhibition at one concentration: 6%
The estimate for compound 4 lay 16 percentage points above the measured number, and the stated range ends above it.
By their numbers in this assay, from the lowest: compound 4; then compounds 2 and 3 (each within the scatter of the next).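

In this assay, within the data shown here, the change from 4-methoxyphenyl to 2-nitrophenyl on a sulfonyl sulfur whose other neighbours are oxygen on an aromatic ring now has a direct measure: it gives a number 22 percentage points lower from compound 3 to compound 4 (beyond the scatter) and so lowers inhibition of growth, which the earlier compounds, with no step between them, could not show. With 2-nitrophenyl held in place, methyl in place of chloro on an aromatic carbon gives a number 14 percentage points lower from compound 2 to compound 4 (beyond the scatter) in the same read-out, so this change in a second place also moves the number, and both steps are modest. Nothing measured here bears on why either step arises.

Steps to compound 1, which has no number, cannot be read, so its place in this order stays unknown. The compounds shown also leave open how a sulfonyl sulfur carrying an aminophenyl group or a phenyl ring with a carboxylic acid would read, and whether the 2-nitrophenyl step would keep its size with an ethyl group in place of the methyl of compound 4.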